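Replacing the 1H-indol-4-yl group of compound 2

The compounds below may be only part of what the source reports. "The series", "measured", "known", "first", "only" and "open" are said of these compounds alone.

- compound 1 (`Cn1c(=O)c(S(=O)(=O)c2ccc(Cl)cc2Cl)cc2cnc(Nc3ccc4[nH]ccc4c3)nc21`): 1000 nM
- compound 2 (`Cn1c(=O)c(S(=O)(=O)c2ccc(F)cc2F)cc2cnc(Nc3cccc4[nH]ccc34)nc21`): 1500 nM

Among the compounds with values here, only two compounds have been measured in a functional assay on K562 cells (Homo sapiens) for inhibition, read by trypan blue exclusion, with a stated time of 72 h; on this read-out lower numbers stand for stronger inhibition and higher numbers for weaker inhibition. Compound 2 gives 1500 nM, the higher of the two numbers, but this lies within the scatter of compound 1 at 1000 nM, so the two cannot be told apart.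

Compound 3 (`Cn1c(=O)c(S(=O)(=O)c2ccc(F)cc2F)cc2cnc(Nc3ccc4c(c3)CC(=O)N4)nc21`) keeps the rest of compound 2 and changes one group, on a nitrogen on an aromatic ring: a group of 10 heavy atoms (8 carbon, 1 nitrogen, 1 oxygen; one five-membered non-aromatic ring with 1 hetero atom, one six-membered aromatic ring of carbon only) in place of a group of 9 heavy atoms (8 carbon, 1 nitrogen; one five-membered aromatic ring with 1 hetero atom, one six-membered aromatic ring of carbon only), on a nitrogen on an aromatic ring. The 1H-indol-4-yl group leaves, and a group with a five-membered non-aromatic ring and a six-membered aromatic ring of carbon only enters.

Within the data shown here, no measured pair shows this change on its own, so the data offer no direct guide. Compound 1 and compound 2 differ in more than one place, yet compound 1 at 1000 nM and compound 2 at 1500 nM stay within the scatter of each other. On that slim basis, only a small shift towards a lower number is expected, with nothing beyond the scatter. The expected step is a 1.7-fold lower number from compound 2 to compound 3 (0.22 log units; within the scatter). For compound 3 the estimated value is 900 nM, with an expected range from 280 nM to 2800 nM.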

Compound 3, half-maximal inhibitory concentration: 15000 nM
Compound 3: the middle estimate sits 17-fold (1.22 log units) below what was measured; measured number above the stated range.
By their numbers in this assay, from the lowest: compounds 1 and 2 (each within the scatter of the next); then compound 3.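

In this assay, replacing the 1H-indol-4-yl group, on a nitrogen on an aromatic ring, with the group containing a five-membered non-aromatic ring gives a 10-fold higher number from compound 2 to compound 3 (1.00 log units; beyond the scatter). This shows that the number responds to the group at this place, which compound 1 and compound 2 could not show, as they differ in more than one place and stay within the scatter of each other. No measurement at hand bears on why the number moves with this change.

The entering group differs from the 1H-indol-4-yl group in its five-membered ring, its oxygen and its hydrogen-bond acceptor all at once, so the compounds shown do not separate these features, and the single step cannot say which of them goes with the higher number. Also open, on these data alone, is how the number would respond to an amine or a carboxylic acid on the six-membered aromatic ring of this group, and whether the step would hold with the other aromatic group on the sulfonyl of compound 1.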